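Chloro in place of hydrogen on the phenyl of compound 2

This account rests on a few compounds, and the source may have more. Where it says the series, first, only, none or still open, it means among the compounds named here.

Of the compounds shown here, two have been measured in a functional assay on HCT-15 cells (Homo sapiens) for inhibition; a lower number here means a stronger inhibitor of growth, a higher number a weaker inhibitor of growth. Compound 1 `COc1cc(/C=C/C(=O)c2cccc(-n3cc(-c4ccccc4)[nH]c3=O)c2)ccc1O` gives 2730 nM in this assay. Compound 2 `O=C(/C=C/c1cccc(O)c1)c1cccc(-n2cc(-c3ccccc3)[nH]c2=O)c1` gives 3100 nM in this assay. Within the data shown here, compound 2 thus carries the highest of the two numbers, but the only step leading to it, a 1.1-fold higher number from compound 1 to compound 2 (0.06 log units; within the scatter), lies within the scatter, so the two compounds are not separated by this assay. Compound 3 `O=C(/C=C/c1cccc(O)c1)c1cccc(-n2cc(-c3ccc(Cl)cc3)[nH]c2=O)c1` has not yet been measured. It differs from compound 2 in one place: chloro in place of hydrogen on an aromatic carbon, para to a large group; read one bond further out, the difference is phenyl to 4-chlorophenyl. Among the measured compounds shown here, none of the measured steps touches this phenyl ring; the single measured step, a 1.1-fold higher number from compound 1 to compound 2 (0.06 log units; within the scatter), concerns the group on the double-bonded chain carbon and was within the scatter. For the measured compounds named here, no measured step therefore bears on the change from compound 2 to compound 3, and the expectation for this assay is a step no larger than the scatter, in no particular direction. Compound 3 is expected to give about 3000 nM in this assay, with a range of 1200 nM to 7500 nM. The step this estimate implies, a 1.0-fold lower number from compound 2 to compound 3 (0.01 log units; within the scatter), is expected to stay within the scatter.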

Compound 3, concentration for 50% growth inhibition: 2330 nM
Compound 3: the middle estimate sits 1.3-fold (0.11 log units) above what was measured, within the range that was stated.
By their numbers in this assay, from the lowest: compounds 3, 1 and 2 (each within the scatter of the next).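

Chloro in place of hydrogen on the phenyl ring gives the first measured change at this position, which the step between compound 1 and compound 2 did not touch. In this assay the change reads a 1.3-fold lower number from compound 2 to compound 3 (0.12 log units; within the scatter) and so does not separate the 4-chlorophenyl of compound 3 from the phenyl of compound 2, showing that one added chlorine atom, para to a large group, leaves the growth inhibition indistinguishable from that of the unsubstituted ring in this pair. No supporting data are available to explain this result.

Going by these compounds, whether the position stays this flat for other groups remains open: an amine or a carboxylic acid in place of the chloro could leave the number within the scatter or move it beyond, and a single substituent gives no basis for choosing between these outcomes. It is also open whether chloro on this ring would give a similar result alongside the 4-hydroxy-3-methoxyphenyl of compound 1, since the chloro change is shown only with the 3-hydroxyphenyl of compound 2.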